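Cyclopropylsulfonyl for cyclopropylmethyl on the bridged amine nitrogen

This account rests on a few compounds, and the source may have more. Where it says the series, first, only, none or still open, it means among the compounds named here.

Compound 2 `Cn1cc(-c2ncc(C#N)c(N3C[C@@H]4C[C@H]3CN4CC3CC3)n2)cn1` carries cyclopropylmethyl on the amine nitrogen in a ring of its bridged system. In an ADME assay on microsomes from liver (Homo sapiens) for pharmacokinetics (a lower number here means slower removal, a higher number faster removal of the compound), compound 2 gives < 16 mL/min/kg, which is a limit of the assay rather than a number. Compound 2 therefore stands at the limit of < 16 mL/min/kg in this assay, at which 2 of the 3 values shown sit. For context, compound 1 `C[C@@H]1CN(c2nc(-c3cnn(C)c3)cnc2C#N)CCN1C(=O)C1CC1` gives 50 mL/min/kg in this assay. Compound 3 `C[C@@H]1CN(c2cnc(C#N)c(-c3cnn(C)c3)n2)CCN1C(=O)C1CC1` gives < 16 mL/min/kg in this assay, again only a limit. Compound 4 `Cn1cc(-c2ncc(C#N)c(N3C[C@@H]4C[C@H]3CN4S(=O)(=O)C3CC3)n2)cn1` differs from compound 2 by cyclopropylsulfonyl in place of cyclopropylmethyl on an amine nitrogen in a ring. Among the measured compounds shown here, no measured pair isolates this change, so its size is open. Given (the limit of < 16 mL/min/kg in this assay, at which 2 of the 3 values shown sit), compound 4 is expected to give about 18 mL/min/kg, with a range of 8 mL/min/kg to 40 mL/min/kg. The expected step of an at least 1.1-fold higher number from compound 2 to compound 4 (0.05 log units; that floor lies within the scatter) is small, within the usual scatter.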

Compound 4, clearance: < 16 mL/min/kg
Compound 4 was reported as a limit (the forecaster's own chance of this, stated with the estimate: 45%); at least 1.1-fold (0.05 log units) between middle value and limit.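

Among the compounds shown here, compound 2 and compound 4 are both reported only as limits in this assay, so no step between them can be read: the limit of < 16 mL/min/kg in this assay, at which 3 of the 4 values shown sit.

The compounds shown leave open the size and direction of the change from cyclopropylmethyl to cyclopropylsulfonyl on the amine nitrogen in a ring.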